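The source may hold more compounds than are shown below. What is called first, only, known or untested is meant among the compounds shown, and "the series" means these compounds.

Compound 1 `COC(=O)c1cc(-c2cccc(NC(=O)c3ccc(OCc4ccc(Cl)cc4)cc3)c2)on1`: in an ADME assay on Vero cells (Chlorocebus sabaeus) for cytotoxicity, read by MTT assay, with a stated time of 72 h (a higher number here means that more compound is tolerated, a lower number that less compound is tolerated), compound 1 gives > 80 ug/mL, a limit of the assay.
Compound 2 `COC(=O)c1cc(-c2cccc(NC(=O)c3ccc(/C=C/C(=O)c4cccs4)cc3)c2)on1`: compound 2 gives "not determined" (no result reported).
Compound 3 `COC(=O)c1cc(-c2cccc(NC(=O)c3ccc(/C=C/C(=O)c4ccc(C)cc4)cc3)c2)on1`: compound 3 gives > 80 ug/mL, again a limit.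

Compound 3 therefore stands at the upper edge of what this assay reports, a position shared by two of the three entries (the limit of > 80 ug/mL in this assay, at which 2 of the 3 values shown sit). Within the data shown here, the one measured step, a step that the two limits leave unreadable from compound 1 to compound 3, cannot be read because both ends are limits. Compound 4 `COC(=O)c1cc(-c2cccc(NC(=O)c3ccc(/C=C/C(=O)c4ccc(C)c(F)c4)cc3)c2)on1` differs from compound 3 by fluoro in place of hydrogen on an aromatic carbon. Among the measured compounds shown here, no measured step with a readable size bears on this change, so no shift beyond the scatter is expected in this assay; the step that the limit leaves unreadable from compound 3 to compound 4 is estimated to stay within the scatter. Compound 4 is expected to give 100 ug/mL, with a range from 40 ug/mL to 250 ug/mL.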

Compound 4, half-maximal cytotoxic concentration: > 50 ug/mL
Compound 4: a limit, no number (the forecaster's own chance of this, stated with the estimate: 75%); the middle value is on the limit's open side.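

Compound 1, compound 3 and compound 4 all return only limits, and the steps from compound 1 and from compound 3 to compound 4 cannot be read. The compounds shown leave open the concentration at which any of them harms the cells.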